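The source may report more compounds than this note shows. Statements on the series, on what has been measured and on what is new or still open speak of the compounds shown alone.

Measured so far:
compound 1, `Oc1ccc(-c2cc(-c3ccncc3)nc(-c3cccc(Cl)c3)c2)cc1`, 29.2%
compound 2, `Oc1ccc(-c2cc(-c3ccc(Cl)cc3)nc(-c3ccco3)c2)cc1`, 15.8%

In an assay on isolated protein for inhibition of DNA topoisomerase 1 (Homo sapiens), with a stated time of 30 min, tested at 100 uM (a lower number here means a weaker effect, a higher number a stronger effect of the compound at the concentration tested), compound 2 gives 15.8%, the lower of the two numbers shown, and the value of compound 1 stands apart from it by more than the usual scatter. Compound 3, `Oc1ccc(-c2cc(-c3cccc(Cl)c3)nc(-c3ccco3)c2)cc1`, has not yet been measured. It differs from compound 2 in one place: 3-chlorophenyl in place of 4-chlorophenyl on an aromatic carbon. No single-change comparison between measured compounds is available, so compound 3 is expected to move only a little, with a number 6.2 percentage points higher from compound 2 to compound 3 (within the scatter) a step not beyond the scatter. Compound 3 is estimated at 22%, within the range 8% to 38%.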

Compound 3, a percentage reported as inhibition, at one concentration (the size of the read-out at that concentration, not a potency): 25.5%
Compound 3: middle estimate off by 3.5 percentage points, on the low side; measured number inside the range.
By their numbers in this assay, from the lowest: compounds 2, 3 and 1 (each within the scatter of the next, the first and the last beyond it).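

In this assay, moving the chlorine from 4-chlorophenyl to 3-chlorophenyl on this aromatic carbon gives a number 9.7 percentage points higher from compound 2 to compound 3 (within the scatter) and so does not clearly separate the two chlorophenyl groups. Furan-2-yl in place of pyridin-4-yl gives a number 3.7 percentage points lower from compound 1 to compound 3 (within the scatter) and so also stays inside the usual variation between repeats. Nothing available explains either step. On these data alone, whether an amine or a carboxylic acid in place of the chlorine would move the number beyond the scatter stays open. So does whether the chlorine shift behaves alike with pyridin-4-yl in place of furan-2-yl.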